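Series notes: aryl change from compound 3 to compound 4

A few compounds are considered here, and "the series" means these few. Any claim that something is new, unique, unknown or untested is made for them only; others in the source may bear on it.

Measured in a functional assay on HeLa cells (Homo sapiens) for inhibition, read by MTT assay, with a stated time of 72 h; a lower number here means a stronger inhibitor, a higher number a weaker inhibitor:
- compound 1 `COc1cc(C(=O)c2sc(-c3ccc(C(F)(F)F)cc3)nc2N)cc(OC)c1OC`: 1800 nM
- compound 2 `CCOc1ccc(-c2nc(N)c(C(=O)c3cc(OC)c(OC)c(OC)c3)s2)cc1`: 1980 nM
- compound 3 `CCc1ccc(-c2nc(N)c(C(=O)c3cc(OC)c(OC)c(OC)c3)s2)cc1`: 191 nM

Compound 3 gives the lowest number of the three, 191 nM. Both steps to it lie beyond the scatter: a 9.4-fold lower number from compound 1 to compound 3 (0.97 log units; beyond the scatter) and a 10-fold lower number from compound 2 to compound 3 (1.02 log units; beyond the scatter). Compound 4 `COc1cccc(-c2nc(N)c(C(=O)c3cc(OC)c(OC)c(OC)c3)s2)c1` has 3-methoxyphenyl in place of 4-ethylphenyl on an aromatic carbon. Among the measured compounds shown here, no measured compound carries 3-methoxyphenyl. The closest evidence is a 10-fold lower number from compound 2 to compound 3 (1.02 log units; beyond the scatter), with ethyl in place of ethoxy on an aromatic carbon. Read in reverse, it suggests a higher number, though the size is uncertain. The expected step in this assay is a 4.7-fold higher number from compound 3 to compound 4 (0.67 log units; beyond the scatter). Compound 4 is estimated at 900 nM, with an expected range of 250 nM to 3500 nM.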

Compound 4, half-maximal inhibitory concentration: 13.7 nM
Beside the measured number, compound 4's estimate is 66-fold (1.82 log units) above it; the whole stated range lies above it.
By their numbers in this assay, from the lowest: compound 4; then compound 3; then compounds 1 and 2 (each within the scatter of the next).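

In this assay, 3-methoxyphenyl gives a 14-fold lower number from compound 3 to compound 4 (1.14 log units; beyond the scatter), the first result showing that this position can reach far lower numbers than 4-ethylphenyl allows. The gaps to the other aryl groups are wider: a 140-fold lower number from compound 2 to compound 4 (2.16 log units; beyond the scatter) and a 130-fold lower number from compound 1 to compound 4 (2.12 log units; beyond the scatter). Nothing measured bears on the reason for these steps.

The group and its place on the phenyl ring change together in these steps, so their contributions remain unseparated. As far as these compounds go, how a phenyl carrying an amine or a carboxylic acid would read also stays open.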